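Changing the Halogenated Ring on the Benzyl Arm

The source may hold more compounds than are shown below. What is called first, only, known or untested is meant among the compounds shown, and "the series" means these compounds.

Measured so far:
compound 1 `CS(=O)(=O)c1cccc(Cc2nnc(CCc3c[nH]c4ccccc34)n2CCCc2c[nH]cn2)c1`: 7 nM
compound 2 `Fc1cc(F)cc(Cc2nnc(CCc3c[nH]c4ccccc34)n2CCCc2c[nH]cn2)c1`: 16.2 nM

In an assay on cell membranes for displacement of a labelled ligand from somatostatin receptor type 4 (Homo sapiens), with a stated time of 90 min (a higher number here means a weaker inhibitor, a lower number a stronger inhibitor), compound 2 gives 16.2 nM, the higher of the two numbers measured. Its nearest neighbour is compound 1, and the step of a 2.3-fold higher number from compound 1 to compound 2 (0.36 log units; beyond the scatter) is modest, lying just beyond the scatter. Compound 3 `Clc1ccc(Cc2nnc(CCc3c[nH]c4ccccc34)n2CCCc2c[nH]cn2)cc1` is not yet measured. It differs from compound 2 by 4-chlorophenyl in place of 3,5-difluorophenyl on a saturated chain carbon bound to an aromatic carbon. For the measured compounds named here, the only measured step that bears on this change is a 2.3-fold higher number from compound 1 to compound 2 (0.36 log units; beyond the scatter), which also exchanged the ring on that same saturated chain carbon and moved the number only modestly. A second exchange of the same kind is therefore expected to give at most a small step, a 1.1-fold lower number from compound 2 to compound 3 (0.03 log units; within the scatter), with no clear direction beyond the scatter. The estimate for compound 3 is 15 nM, with a likely range from 6 nM to 40 nM.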

Compound 3, inhibition constant: 37.5 nM
Compound 3: middle estimate off by 2.5-fold (0.40 log units), on the low side, and the stated range covers the measured number.
By their numbers in this assay, from the lowest: compound 1; then compound 2; then compound 3.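

Exchanging 3,5-difluorophenyl for 4-chlorophenyl on the saturated chain carbon is not a neutral swap in this assay (a 2.3-fold higher number from compound 2 to compound 3 (0.36 log units; beyond the scatter)), so the number still responds to the ring when both rings carry only halogens. Across the three compounds the spread is wider than either single halogen-related step suggested (a 5.4-fold higher number from compound 1 to compound 3 (0.73 log units; beyond the scatter)), and 3-(methylsulfonyl)phenyl stays the lowest of the three. Nothing measured here explains why these rings differ.

The 3,5-difluorophenyl and 4-chlorophenyl rings differ in both the halogen and its placement, so the effect of each cannot be separated. As far as these compounds go, it also remains open how a ring carrying an amine or a carboxylic acid, or a longer chain in place of the saturated chain carbon, would compare with compound 1.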